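Removing one chloro from the core of compound 2

The source may report more compounds than this note shows. Statements on the series, on what has been measured and on what is new or still open speak of the compounds shown alone.

Of the compounds shown here, two have been measured in a functional assay on SF-539 cells (Homo sapiens) for cytotoxicity, read by sulforhodamine B assay, with a stated time of 48 h; a higher number here means a weaker inhibitor of growth, a lower number a stronger inhibitor of growth. Compound 1 `ClCc1ccc(Cn2cnc3c(Cl)ncnc32)cc1` gives 1170 nM in this assay. Compound 2 `ClCc1ccccc1Cn1cnc2c(Cl)nc(Cl)nc21` gives 2880 nM in this assay, the highest of the two numbers, and its nearest neighbour is compound 1, whose number is lower by a margin beyond the scatter. Compound 3 `ClCc1ccccc1Cn1cnc2c(Cl)ncnc21` has not yet been measured. It differs from compound 2 in one place: hydrogen in place of chloro on an aromatic carbon, so its core becomes that of compound 1 while the chloromethyl-bearing benzyl group of compound 2 is kept. For the measured compounds named here, no measured pair shows this step on its own, so its size is not known from the data. Since compound 1, which carries the same core, gives 1170 nM, compound 3 is expected to land between the two measured numbers, with a step of a 1.7-fold lower number from compound 2 to compound 3 (0.23 log units; within the scatter) that may stay within the scatter. The estimate for compound 3 in this assay is 1700 nM, with a range from 600 nM to 5000 nM.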

Compound 3, concentration for total growth inhibition: 24000 nM
Compound 3: middle estimate off by 14-fold (1.15 log units), on the low side, and the stated range ends below it.
By their numbers in this assay, from the lowest: compound 1; then compound 2; then compound 3.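

In this assay, for the compounds shown here, the chloro on the aromatic carbon between two ring nitrogen atoms matters far more than the earlier compounds suggested: hydrogen in its place weakens growth inhibition (an 8.3-fold higher number from compound 2 to compound 3 (0.92 log units; beyond the scatter)). The core of compound 1 therefore does not bring a low number with it, since compound 1 gives 1170 nM while, with the same core and the chloromethyl-bearing benzyl group of compound 2, compound 3 gives 24000 nM. Nothing available explains the size of this step.

As far as these compounds go, it remains open whether an amine or a methoxy group on this carbon would hold the number of compound 2 or follow that of compound 3. From the compounds shown here alone, it is also open whether adding this chloro to compound 1 would bring a change of similar size.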